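A few compounds are considered here, and "the series" means these few. Any claim that something is new, unique, unknown or untested is made for them only; others in the source may bear on it.

Working notes on the series.

Compound 3 `CC(C)=CCC/C(C)=C/CC1Cc2c(OC(=O)Nc3cccc(F)c3)cc(=O)n(CCCO)c2CC1(C)C` carries a (3-fluorophenyl)carbamoyl group on the ring oxygen and, in a functional assay on PANC-1 cells (Homo sapiens) for inhibition, read by MTT assay, with a stated time of 24 h, tested at 10 uM (a lower number here means less inhibition, a higher number more inhibition at the concentration tested (going by the name of the read-out)), compound 3 gives 52.3%. Among the three compounds with numbers, compound 3 stands level with compound 1 `CC(C)=CCC1Cc2c(OC(=O)Nc3ccccc3F)cc(=O)n(CCCO)c2CC1(C)C`, which in this assay gives 52.3%; the two are not separated at the digits recorded and together sit at the top of the set. The low end is compound 2 `CC(C)=CCC/C(C)=C/CC1Cc2c(OCCCOc3ccc(Cl)cc3)cc(=O)n(CCCO)c2CC1(C)C`, which in this assay gives 25.2%. Within the data shown here, the one single-point step measured so far runs a number 27.1 percentage points higher from compound 2 to compound 3 (beyond the scatter), a modest rise that comes from the (3-fluorophenyl)carbamoyl group in place of the 3-(4-chlorophenoxy)propyl group.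

Compound 4 `CC(C)=CCC/C(C)=C/CC1Cc2c(OC(=O)Nc3ccccc3F)cc(=O)n(CCCO)c2CC1(C)C` differs from compound 3 only as follows: 2-fluorophenyl in place of 3-fluorophenyl on an amide-type nitrogen. Among the measured compounds shown here, no measured step addresses this exact change. Compound 1 also bears a 2-fluorophenyl group on the carbamate nitrogen, though on a different core, and its value and that of compound 3 are indistinguishable; this is the only bearing the data give. The change from compound 3 to compound 4 is therefore expected to move this assay by no more than the scatter, that is a number 0.3 percentage points lower from compound 3 to compound 4 (within the scatter). Compound 4 is expected to give about 52%, within 38% to 66%.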

Compound 4, a percentage reported as inhibition, at one concentration (the size of the read-out at that concentration, not a potency): 71.6%
Estimate against measurement, compound 4: 19.6 percentage points below, outside the stated range (above it).
By their numbers in this assay, from the lowest: compound 2; then compounds 1 and 3 (each within the scatter of the next); then compound 4.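

Among these compounds, on the amide-type nitrogen the choice of fluorophenyl group is not silent: 2-fluorophenyl in place of 3-fluorophenyl gives a number 19.3 percentage points higher from compound 3 to compound 4 (beyond the scatter) in this assay on an otherwise unchanged structure, a difference the earlier compounds could not show, since compound 1 and compound 3 differ in two places and their equal values gave no reading of either change alone. With the (2-fluorophenyl)carbamoyl group held fixed, the side chain also counts, as 3-methylbut-2-en-1-yl in place of hydrogen on a saturated chain carbon bound to a double-bonded chain carbon gives a number 19.3 percentage points higher from compound 1 to compound 4 (beyond the scatter) in this assay. The replacement of 3-(4-chlorophenoxy)propyl on the ring oxygen, already seen with the 3-fluorophenyl carbamate, now reaches a number 46.4 percentage points higher from compound 2 to compound 4 (beyond the scatter) with the 2-fluorophenyl carbamate.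

Still open, going by these compounds, is whether an unsubstituted phenyl, a 2-chlorophenyl or a 2-methoxyphenyl group on the same nitrogen would follow compound 4 or compound 3, and whether the side-chain step carries over to the 3-fluorophenyl carbamate. No available evidence bears on what lies behind these differences.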